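The compounds below may be only part of what the source reports. "The series", "measured", "known", "first", "only" and "open" are said of these compounds alone.

Measured so far in a functional assay on MCF7 cells (Homo sapiens) for inhibition, read by MTT assay, with a stated time of 72 h (a higher number here means a weaker inhibitor, a lower number a stronger inhibitor), as follows:

Compound 1 `C=CCc1ccc(OCc2ccc(Cl)cc2Cl)c(-c2ccc(OCc3ccc(Cl)cc3Cl)c(CC=C)c2)c1` gives > 50000 nM as a limit of the assay
Compound 2 `C=CCc1ccc(OCc2ccc(Cl)cc2Cl)c(-c2ccc(O)c(CC=C)c2)c1` gives 27400 nM as a number
Compound 3 `C=CCc1ccc(O)c(-c2ccc(OCc3ccc(Cl)c(Cl)c3)c(CC=C)c2)c1` gives 15300 nM as a number

Within the data shown here, compound 2 at 27400 nM lies within the scatter of compound 3 at 15300 nM and these are the only two true numbers in the set. Compound 1 shows only the limit > 50000 nM and no number.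

Next is compound 4 `C=CCc1ccc(OCc2ccccc2)c(-c2ccc(O)c(CC=C)c2)c1`, with this change from compound 2: phenyl in place of 2,4-dichlorophenyl on a saturated chain carbon bound to an oxygen on an aromatic ring. Among the measured compounds shown here, the one measured step touching this group is an at least 1.8-fold lower number from compound 1 to compound 2 (0.26 log units; that floor lies within the scatter) and it removes the whole 2,4-dichlorobenzyl rather than trimming it. Its floor stays within the scatter, so it gives no ground for a shift in either direction in this assay, and none beyond the scatter is expected. The estimated step is a 1.1-fold lower number from compound 2 to compound 4 (0.04 log units; within the scatter) and it stays within the scatter. For compound 4 the estimated value is 25000 nM with 12000 nM to 55000 nM as the expected range.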

Compound 4, half-maximal inhibitory concentration: 22300 nM
Beside the measured number, compound 4's estimate is 1.1-fold (0.05 log units) above it; the range from low to high includes it.
By their numbers in this assay, from the lowest: compounds 3, 4 and 2 (each within the scatter of the next). At a limit, above all of these: compound 1.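

Phenyl in place of 2,4-dichlorophenyl on a saturated chain carbon bound to an oxygen on an aromatic ring gives, in this assay, a 1.2-fold lower number from compound 2 to compound 4 (0.09 log units; within the scatter). Unlike the earlier step at this oxygen, which removes the whole 2,4-dichlorobenzyl and rests on a limit, this step trims only the ring and joins two true numbers. The chlorine atoms are therefore not needed to keep a measurable number in this pair, while compound 1 is the one compound that stands at a limit of the assay: the limit of > 50000 nM in this assay, at which 1 of the 4 values shown sits.

Going by these compounds, what an amine or a carboxylic acid on this benzyl ring, or a longer chain in place of benzyl, would do in this assay stays open. On these data alone, a single chlorine on this ring also remains open, as this pair cannot tell the contribution of each chlorine.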